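The source may hold more compounds than are shown below. What is called first, only, known or untested is meant among the compounds shown, and "the series" means these compounds.

In an ADME assay on BJ cells (Homo sapiens) for cytotoxicity, read by luminescence, with a stated time of 72 h (on this read-out higher numbers stand for an effect only at larger amounts of compound and lower numbers for an effect already at smaller amounts), compound 1 (`CCOC(=O)c1c(-c2ccccc2)[nH]c2cc(OC)ccc2c1=O`) reads > 21500 nM as a limit of the assay. Compound 2 (`CCOC(=O)c1c(-c2cccc(OC(F)(F)F)c2)[nH]c2cc(OC)ccc2c1=O`) reads > 21500 nM as a limit as well. Compound 3 (`CCOC(=O)c1c(-c2cccc(OC(F)(F)F)c2)[nH]c2cc(OC)c(F)cc2c1=O`) reads > 21500 nM as a limit too, so its position is known only as a bound, and it shares that bound with the other two (the limit of > 21500 nM in this assay, at which 3 of the 3 values shown sit).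

Compound 4 (`CCOC(=O)c1c(-c2cccc(-c3nc(C)c(C)s3)c2)[nH]c2cc(OC)c(F)cc2c1=O`) differs from compound 3 by 4,5-dimethyl-1,3-thiazol-2-yl in place of trifluoromethoxy on an aromatic carbon. The trifluoromethoxy entry (a step that the two limits leave unreadable from compound 1 to compound 2) bears on this most directly and the fluoro entry (a step that the two limits leave unreadable from compound 2 to compound 3) less so, but neither has a readable size. Within the data shown here, no measured compound carries the entering group.

With nothing but limits to go on, no clear change is expected in this assay beyond the scatter, with a small allowance for an effect at smaller amounts. The expected step is an at least 1.0-fold lower number from compound 3 to compound 4 (0.03 log units; that floor lies within the scatter) and it may well stay unreadable. For compound 4 the estimate is 20000 nM with an expected range from 7000 nM to 40000 nM and a limit is the likeliest outcome.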

Compound 4, half-maximal effective concentration: > 21500 nM
Compound 4: a limit, no number; the forecaster's own chance of this, stated with the estimate: 65%; middle value at least 1.0-fold (0.03 log units) away from the limit.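

Compound 3 and compound 4 give no readable step, because both values are limits of the assay: the limit of > 21500 nM in this assay, at which 4 of the 4 values shown sit.

The compounds shown leave open at what amount any of them would reach a half-maximal effect in this assay, and whether any exchange of groups shifts that amount.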